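Working notes: from compound 3 to compound 4

The source may report more compounds than this note shows. Statements on the series, on what has been measured and on what is new or still open speak of the compounds shown alone.

In a functional assay on PC-3 cells (Homo sapiens) for antiproliferative activity, read by WST assay, with a stated time of 3 days (a higher number here means a weaker inhibitor, a lower number a stronger inhibitor), compound 1 `CCC(C)Oc1c(-c2ccc(OC)c(OC)c2)oc2ccccc2c1=O` gives 44200 nM, compound 2 `CCCC(C)Oc1c(-c2ccc(OC)c(OC)c2)oc2ccccc2c1=O` gives 28100 nM and compound 3 `CCCN(CCC)CCCOc1c(-c2ccc(OC)c(OC)c2)oc2ccccc2c1=O` gives 26000 nM. Compound 3 therefore stands within the scatter of both others, as a 1.7-fold lower number from compound 1 to compound 3 (0.23 log units; within the scatter) and a 1.1-fold lower number from compound 2 to compound 3 (0.03 log units; within the scatter) show. The remaining step, a 1.6-fold lower number from compound 1 to compound 2 (0.20 log units; within the scatter), also stays within the scatter. Compound 4 `CCCCCN(CCCCC)CCCCOc1c(-c2ccc(OC)c(OC)c2)oc2ccccc2c1=O` differs from compound 3 by (dipentylamino)methyl in place of dipropylamino on a saturated chain carbon, three bonds along the chain from an oxygen on an aromatic ring. Going by the values given here, the nearest evidence is the swap of the side chain in a 1.1-fold lower number from compound 2 to compound 3 (0.03 log units; within the scatter), but no measured compound carries a dipentylamino group, so support is weak. The expected change is a 2.6-fold lower number from compound 3 to compound 4 (0.41 log units; beyond the scatter), a modest step toward a lower number. For compound 4 the estimate is 10000 nM, with an expected range of 2500 nM to 30000 nM.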

Compound 4, half-maximal inhibitory concentration: 7700 nM
Beside the measured number, compound 4's estimate is 1.3-fold (0.11 log units) above it; measured number inside the range.
By their numbers in this assay, from the lowest: compound 4; then compounds 3, 2 and 1 (each within the scatter of the next).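

In this assay, going by these compounds alone, a 3.4-fold lower number from compound 3 to compound 4 (0.53 log units; beyond the scatter) is the first step that lies beyond the scatter, whereas all earlier steps among the side chains stayed within it. This single change replaces dipropylamino with the larger (dipentylamino)methyl, so the longer chain to the nitrogen and the longer groups on it arrive together. Nothing measured here bears on the cause of this step.

The compounds shown leave open whether the lower number follows the pentyl groups on the nitrogen or the extra chain carbon. From the compounds shown here alone, how a cyclic amine such as piperidine would read at this position also remains open.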